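A few compounds are considered here, and "the series" means these few. Any claim that something is new, unique, unknown or untested is made for them only; others in the source may bear on it.

Compound 1 `CC1(C)c2[nH]nc(NC(=O)c3ccc(Br)cc3)c2CN1Cc1cccc(F)c1F` is measured in an assay on Sf21 cells for inhibition of high affinity nerve growth factor receptor (Homo sapiens), read by HTRF, with a stated time of 30 min, in the presence of a further agent that is not named here (a higher number here means a weaker inhibitor, a lower number a stronger inhibitor), and gives 950 nM. Compound 2 `CC1(C)c2[nH]nc(NC(=O)c3ccc(Br)cc3)c2CN1Cc1cc(F)cc(F)c1` carries 3,5-difluorophenyl in place of 2,3-difluorophenyl on a saturated chain carbon bound to an amine nitrogen in a ring; in this assay compound 2 gives 710 nM, a step of a 1.3-fold lower number from compound 1 to compound 2 (0.13 log units; within the scatter). Compound 3 `CN(C)c1ccc(C(=O)Nc2n[nH]c3c2CN(Cc2cccc(F)c2F)C3(C)C)cc1` differs from compound 1 by dimethylamino in place of bromo on an aromatic carbon; in this assay compound 3 gives 69 nM, the step being a 14-fold lower number from compound 1 to compound 3 (1.14 log units; beyond the scatter). Of the three measured compounds, compound 3 has the lowest number, and both of its steps to the others lie beyond the scatter.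

Compound 4 `CN(C)c1ccc(C(=O)Nc2n[nH]c3c2CN(Cc2cc(F)cc(F)c2)C3(C)C)cc1` has not yet been measured. It differs from compound 3 by 3,5-difluorophenyl in place of 2,3-difluorophenyl on a saturated chain carbon bound to an amine nitrogen in a ring, the same change that separates compound 1 from compound 2, made at the same place. The two cores differ by dimethylamino in place of bromo on an aromatic carbon. Because the earlier step of a 1.3-fold lower number from compound 1 to compound 2 (0.13 log units; within the scatter) lay within the scatter, compound 4 is expected to show a step of about a 1.3-fold lower number from compound 3 to compound 4 (0.10 log units; within the scatter). Compound 4 is therefore estimated at 55 nM in this assay, with a range from 25 nM to 120 nM.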

Compound 4, half-maximal inhibitory concentration: 96 nM
Compound 4: the middle estimate sits 1.7-fold (0.24 log units) below what was measured; the range from low to high includes it.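

In this assay, the change from 2,3-difluorobenzyl to 3,5-difluorobenzyl gives a 1.4-fold higher number from compound 3 to compound 4 (0.14 log units; within the scatter), and on the bromo core it stayed just as small, so the two readings agree: the same change on two cores in this assay, a 1.3-fold lower number (0.13 log units; within the scatter) from compound 1 to compound 2 and a 1.4-fold higher number (0.14 log units; within the scatter) from compound 3 to compound 4, 1.9-fold (0.27 log units) apart, within the scatter of two such steps The exchange of bromo for dimethylamino, read on the 3,5-difluorobenzyl pair, gives a 7.4-fold lower number from compound 2 to compound 4 (0.87 log units; beyond the scatter), which agrees with its size on the 2,3-difluorobenzyl pair: the same change on two cores in this assay, a 14-fold lower number (1.14 log units; beyond the scatter) from compound 1 to compound 3 and a 7.4-fold lower number (0.87 log units; beyond the scatter) from compound 2 to compound 4, 1.9-fold (0.27 log units) apart, within the scatter of two such steps Across these four compounds, each change therefore carries from one core to the other within the scatter, but this rests on a single set of two cores and two benzyl groups, and a benzyl change that stays within the scatter on both cores does not show that a larger step at that place would carry over too.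

On these data alone, it remains open whether a piperazine in place of dimethylamino, or an unsubstituted benzyl in place of the difluorobenzyl groups, would follow the same pattern. The compounds shown also leave open whether the pattern extends beyond these four compounds.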